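The source may hold more compounds than are shown below. What is called first, only, known or untested is meant among the compounds shown, and "the series" means these compounds.

Measured compounds:
- compound 1, `O=C(NO)c1ccc(NCc2nc(-c3ccccc3)nn2-c2ccc(Br)cc2)cc1`: 65.9%
- compound 2, `O=C(NO)c1ccc(NCc2nc(-c3ccc(C(F)(F)F)cc3)nn2-c2ccccc2)cc1`: 41.6%

In an assay on Sf9 cells for inhibition of protein deacetylase HDAC6 (Homo sapiens), read by fluorescence, with a stated time of 40 min, tested at 100 nM (a lower number here means less inhibition, a higher number more inhibition at the concentration tested (going by the name of the read-out)), compound 1 gives 65.9%, the higher of the two numbers in hand. Compound 2 gives 41.6% in this assay, a gap that lies beyond the usual scatter. Among the measured compounds shown here, compound 2 differs from compound 1 in more than one place, so no single step between the measured compounds can be read off.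

The new compound is compound 3, `CCc1ccc(-n2nc(-c3ccccc3)nc2CNc2ccc(C(=O)NO)cc2)cc1`. It differs from compound 1 by ethyl in place of bromo on an aromatic carbon. For the measured compounds named here, no measured pair shows this change, so its effect is not known from the numbers in hand. The change is small and keeps the rest of compound 1 intact, so the step from compound 1 to compound 3 is expected to be a number 5.9 percentage points lower from compound 1 to compound 3 (within the scatter), within the scatter. Compound 3 is therefore estimated to give 60% in this assay, with a range from 45% to 75%.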

Compound 3, a percentage reported as inhibition, at one concentration (the size of the read-out at that concentration, not a potency): 38.3%
Beside the measured number, compound 3's estimate is 21.7 percentage points above it; measured number outside the range, below it.
By their numbers in this assay, from the lowest: compounds 3 and 2 (each within the scatter of the next); then compound 1.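

Among the compounds shown here, the change from 4-bromophenyl to 4-ethylphenyl gives a number 27.6 percentage points lower from compound 1 to compound 3 (beyond the scatter) in this assay and is the only step in the set that differs in one place. It shows that the group on this aromatic carbon, para to a large group, matters to the inhibition read at the concentration tested: with the rest of compound 1 unchanged, ethyl in place of bromo does not hold the reading. Nothing measured here explains the drop.

The compounds shown leave open whether the loss is particular to ethyl or would follow with other groups at this place, such as chloro, methoxy, an amine or a carboxylic acid. They also leave open whether a longer chain would lower the reading further or restore it.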